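A Dihydroxyphenyl Analogue Expected to Remain Inactive

The source may report more compounds than this note shows. Statements on the series, on what has been measured and on what is new or still open speak of the compounds shown alone.

Compound 1 `CN(C)CCn1cnnc1-c1cc(Oc2ccc(NC(=O)N/N=C/c3c(O)ccc4ccccc34)cc2F)ccn1`: 880 nM
Compound 2 `CN(C)CCn1cnnc1-c1cc(Oc2ccc(NC(=O)N/N=C/c3c[nH]c4ccccc34)cc2F)ccn1`: 820 nM
Compound 3 `COc1cc(/C=N/NC(=O)Nc2ccc(Oc3ccnc(-c4nncn4CCN(C)C)c3)c(F)c2)ccc1O`: > 100000 nM

In a functional assay on A549 cells (Homo sapiens) for cytotoxicity, read by MTT assay, with a stated time of 72 h (a higher number here means a weaker inhibitor, a lower number a stronger inhibitor), compound 1 gives 880 nM and compound 2 gives 820 nM; the step of a 1.1-fold lower number from compound 1 to compound 2 (0.03 log units; within the scatter) lies within the scatter. For compound 3 the assay returns only a limit, > 100000 nM, so compound 3 stands at the limit of > 100000 nM in this assay, at which 1 of the 3 values shown sits, rather than at a number. The steps of an at least 110-fold higher number from compound 1 to compound 3 (2.05 log units; beyond the scatter) and an at least 120-fold higher number from compound 2 to compound 3 (2.08 log units; beyond the scatter) are both large. Compound 4 `CN(C)CCn1cnnc1-c1cc(Oc2ccc(NC(=O)N/N=C/c3ccc(O)cc3O)cc2F)ccn1` differs from compound 3 by 2,4-dihydroxyphenyl in place of 4-hydroxy-3-methoxyphenyl on a carbon with a double bond to nitrogen. Going by the values given here, a single six-membered aromatic ring of carbon only is kept, and no measured step points to a recovery from such a ring; a step of an at least 1.2-fold lower number from compound 3 to compound 4 (0.09 log units; that floor lies within the scatter) is expected, within the scatter. Compound 4 is estimated at 80000 nM, between 20000 nM and 300000 nM, most likely again reported only as a limit.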

Compound 4, half-maximal inhibitory concentration: 12700 nM
Compound 4: the middle estimate sits 6.3-fold (0.80 log units) above what was measured, and the stated range ends above it.
By their numbers in this assay, from the lowest: compounds 2 and 1 (each within the scatter of the next); then compound 4. At a limit, above all of these: compound 3.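

In this assay, 2,4-dihydroxyphenyl in place of 4-hydroxy-3-methoxyphenyl gives an at least 7.8-fold lower number from compound 3 to compound 4 (0.89 log units; beyond the scatter), so a single six-membered aromatic ring of carbon only does not by itself place a compound at the limit. That step is only a floor, since the value of compound 3 is a limit: the limit of > 100000 nM in this assay, at which 1 of the 4 values shown sits. The recovery remains partial, with a 15-fold higher number from compound 2 to compound 4 (1.19 log units; beyond the scatter) and a 14-fold higher number from compound 1 to compound 4 (1.16 log units; beyond the scatter). The compounds shown leave open whether an amine or a carboxylic acid in place of a hydroxyl on this ring would keep the gain.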